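The compounds below may be only part of what the source reports. "The series", "measured", "known", "first", "only" and "open" are said of these compounds alone.

Three compounds have been measured in an assay on cells (Hepatocyte) for inhibition of glucokinase regulatory protein (Mus musculus), with stated times of 20 min and 40 min; a lower number here means that less compound is needed, a higher number that more compound is needed for the effect:

Compound 1, `CC#C[C@H]1CN(S(=O)(=O)c2ccc(N)nc2)CCN1c1ccc(S(=N)(=O)C2CC2)cc1`: 208 nM
Compound 2, `CC#C[C@H]1CN(S(=O)(=O)c2ccc(N)nc2)CCN1c1ccc(S(C)(=N)=O)cc1`: 704 nM
Compound 3, `C#CCC(O)(c1ccc(N2CCN(S(=O)(=O)c3ccc(N)nc3)C[C@@H]2C#CC)cc1)C(F)(F)F`: 130 nM

Compound 3 gives the lowest number of the three. One step is a 1.6-fold lower number from compound 1 to compound 3 (0.20 log units; within the scatter), which is within the scatter, while the other is a 5.4-fold lower number from compound 2 to compound 3 (0.73 log units; beyond the scatter), beyond it. Compound 4, `CC#C[C@H]1CN(S(=O)(=O)c2ccc(N)nc2)CCN1c1ccc([C@](O)(CO)C(F)(F)F)cc1`, differs from compound 3 in one place: a group of 8 heavy atoms (3 carbon, 2 oxygen, 3 fluorine; no ring) in place of a group of 9 heavy atoms (5 carbon, 1 oxygen, 3 fluorine; no ring), on an aromatic carbon. Going by the values given here, no measured step replaces this group in the same way. The steps that touch this position show that varied groups there shift the number modestly at most. Compound 4 is therefore expected to show a 1.9-fold higher number from compound 3 to compound 4 (0.28 log units; within the scatter), a slightly higher number than compound 3. Compound 4 is estimated at 250 nM, with a range from 80 nM to 800 nM.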

Compound 4, half-maximal effective concentration: 98 nM
Compound 4: the middle estimate sits 2.6-fold (0.41 log units) above what was measured; measured number inside the range.
By their numbers in this assay, from the lowest: compounds 4, 3 and 1 (each within the scatter of the next, the first and the last beyond it); then compound 2.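

In this assay, the 1,2-dihydroxy-1-(trifluoromethyl)ethyl group holds the number reached by the group it replaces, with a 1.3-fold lower number from compound 3 to compound 4 (0.12 log units; within the scatter), so the triple bond of compound 3 is not required for a number of this size. Unlike compound 3, compound 4 separates from the cyclopropyl-bearing compound, with a 2.1-fold lower number from compound 1 to compound 4 (0.33 log units; beyond the scatter), and it also shows a 7.2-fold lower number from compound 2 to compound 4 (0.86 log units; beyond the scatter). No evidence on the cause of these steps is available. The compounds shown leave open how an amine or a carboxylic acid on this aromatic carbon would compare, and what the opposite configuration at the defined stereocentre would give.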